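The source may report more compounds than this note shows. Statements on the series, on what has been measured and on what is new or still open speak of the compounds shown alone.

Measured compounds in this series:
compound 1 `CN(C(=O)NC(=O)c1ccc(F)c(F)c1)c1nc(C(F)(F)F)c(C(=O)N/N=C/c2ccc(C(F)(F)F)cc2)s1` gives 5.93 ug/mL in a functional assay on MCF7 cells (Homo sapiens) for inhibition, read by MTT assay, with a stated time of 72 h; a higher number here means a weaker inhibitor, a lower number a stronger inhibitor
compound 2 `CN(C(=O)NC(=O)c1c(F)cccc1F)c1nc(C(F)(F)F)c(C(=O)N/N=C/c2cccc(C(F)(F)F)c2)s1` gives 21.8 ug/mL in this assay

Compound 2 stands at the highest number of the two; its nearest neighbour, compound 1, sits at a lower number, and that gap lies beyond the usual scatter. The next compound, compound 3 `CN(C(=O)NC(=O)c1c(F)cccc1F)c1nc(C(F)(F)F)c(C(=O)N/N=C/c2ccc(C(F)(F)F)cc2)s1`, keeps the core of compound 2 and differs in one place: 4-(trifluoromethyl)phenyl in place of 3-(trifluoromethyl)phenyl on a carbon with a double bond to nitrogen. Among the measured compounds shown here, no pair of measured compounds isolates this change. Compound 1 also carries the 4-(trifluoromethyl)phenyl group, but its difluorobenzoyl part differs as well, so its two values together with compound 2 show only the combined effect of both changes. For compound 3 a moderate step toward a lower number is expected, a 1.8-fold lower number from compound 2 to compound 3 (0.26 log units; within the scatter), with no certainty that it clears the scatter. Compound 3 is accordingly estimated at 12 ug/mL, within 5 ug/mL to 30 ug/mL.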

Compound 3, half-maximal inhibitory concentration: 35.3 ug/mL
The estimate for compound 3 lay 2.9-fold (0.47 log units) below the measured number; measured number outside the range, above it.
By their numbers in this assay, from the lowest: compound 1; then compounds 2 and 3 (each within the scatter of the next).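

In this assay, 4-(trifluoromethyl)phenyl in place of 3-(trifluoromethyl)phenyl on a carbon with a double bond to nitrogen gives a 1.6-fold higher number from compound 2 to compound 3 (0.21 log units; within the scatter), so this change does not separate the two compounds when 2,6-difluorophenyl stands on the carbonyl carbon. Among the compounds shown here, with 4-(trifluoromethyl)phenyl held constant, 2,6-difluorophenyl in place of 3,4-difluorophenyl on a carbonyl carbon gives a 6.0-fold higher number from compound 1 to compound 3 (0.77 log units; beyond the scatter), the only single-place step so far that lies beyond the scatter. No measurement at hand accounts for either step.

From the compounds shown here alone, whether the swap between the two trifluoromethylphenyl groups would also stay within the scatter with 3,4-difluorophenyl on the carbonyl carbon remains open. Also open, going by these compounds, is how an amine or a carboxylic acid in place of trifluoromethyl on that phenyl ring would read in this assay.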